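Ethyl in Place of Fluorophenyl: Expected Loss of Potency

The source may hold more compounds than are shown below. What is called first, only, known or untested is meant among the compounds shown, and "the series" means these compounds.

Compound 1, `CCOC(=O)c1cnc(CC)nc1NN1C(=O)C=C(C)C1=O`: 10000 nM in a functional assay on Jurkat cells for inhibition of nuclear factor NF-kappa-B complex (Homo sapiens); a lower number here means a stronger inhibitor, a higher number a weaker inhibitor.
Compound 2, `CCOC(=O)c1cnc(-c2ccc(F)cc2)nc1NN1C(=O)C=C(C)C1=O`: 700 nM in this assay.
Compound 3, `CCOC(=O)c1cnc(-c2ccc(F)cc2)nc1N(C)N1C(=O)C=C(C)C1=O`: 3000 nM in this assay.

Two changes on the shared core have been measured. The change methyl in place of hydrogen on a nitrogen on an aromatic ring gives a 4.3-fold higher number from compound 2 to compound 3 (0.63 log units; beyond the scatter). The change ethyl in place of 4-fluorophenyl on an aromatic carbon gives a 14-fold higher number from compound 2 to compound 1 (1.15 log units; beyond the scatter). Compound 4, `CCOC(=O)c1cnc(CC)nc1N(C)N1C(=O)C=C(C)C1=O`, is not yet measured; it differs from compound 3 by ethyl in place of 4-fluorophenyl on an aromatic carbon. This is the same kind of change as from compound 2 to compound 1, though the surroundings are described differently: meta to a large group in compound 3, meta to a group of 9 heavy atoms in compound 2. In this assay the expected step is a 10-fold higher number from compound 3 to compound 4 (1.00 log units; beyond the scatter), because the same kind of change gave a 14-fold higher number from compound 2 to compound 1 (1.15 log units; beyond the scatter). Compound 4 is therefore estimated at 30000 nM, expected between 8000 nM and 100000 nM. Such a weak number may well be reported only as a limit.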

Compound 4, half-maximal inhibitory concentration: 10000 nM
Beside the measured number, compound 4's estimate is 3.0-fold (0.48 log units) above it; the range from low to high includes it.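

In this assay, ethyl in place of 4-fluorophenyl raises the number on both cores, here with a 3.3-fold higher number from compound 3 to compound 4 (0.52 log units; beyond the scatter), but the size of the step does not carry over: the same change on two cores in this assay, a 14-fold higher number (1.15 log units; beyond the scatter) from compound 2 to compound 1 and a 3.3-fold higher number (0.52 log units; beyond the scatter) from compound 3 to compound 4, 4.3-fold (0.63 log units) apart, beyond the scatter of two such steps. Methyl on the nitrogen does not carry over either, giving no change at the digits printed from compound 1 to compound 4 (within the scatter) on the core with ethyl, although it raised the number on the core with 4-fluorophenyl: the same change on two cores in this assay, a 4.3-fold higher number (0.63 log units; beyond the scatter) from compound 2 to compound 3 and no change at the digits printed (within the scatter) from compound 1 to compound 4, 4.3-fold (0.63 log units) apart, beyond the scatter of two such steps. The direction of the ethyl change held on these two cores, but the four compounds do not show why the steps differ or whether that direction would hold on any other core.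

Going by these compounds, whether an amine or a longer chain on that aromatic carbon would stand closer to ethyl or to 4-fluorophenyl remains open. So does the effect of a carboxylic acid in place of the ethoxycarbonyl group.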